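The compounds below may be only part of what the source reports. "The series", "measured", "known", "first", "only" and "open" are said of these compounds alone.

For the measured compounds named here, in a functional assay on HT-29 cells (Homo sapiens) for antiproliferative activity, read by MTT assay, with a stated time of 48 h (on this read-out lower numbers stand for stronger inhibition and higher numbers for weaker inhibition), compound 2 `COc1cc(-c2nn(-c3ccccc3)cc2C(=O)/C=C\Nc2ccc(F)cc2)cc(OC)c1OC` gives 12500 nM, the only number in this set. Compound 1 `O=C(/C=C\Nc1ccc(C(F)(F)F)cc1)c1cn(-c2ccccc2)nc1-c1ccccc1` is known in this assay only as a limit, > 50000 nM. That limit is the limit of > 50000 nM in this assay, at which 1 of the 2 values shown sits. Going by the values given here, compound 1 and compound 2 differ in more than one place, so no single step between them is drawn here. Compound 3 `COc1cc(-c2nn(-c3ccccc3)cc2C(=O)/C=C\Nc2ccc(C(F)(F)F)cc2)cc(OC)c1OC` is not yet measured in this assay. Relative to compound 2 the change is trifluoromethyl in place of fluoro on an aromatic carbon, with the rest of compound 2 kept. Compound 1 also carries a trifluoromethyl group on its anilino ring and returns only a limit. On that basis compound 3 is expected to show a 2.2-fold higher number from compound 2 to compound 3 (0.35 log units; beyond the scatter) toward weaker inhibition, with a fair chance that only a limit is reported. Compound 3 is estimated at 28000 nM, in a range from 10000 nM to 60000 nM.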

Compound 3, half-maximal inhibitory concentration: > 50000 nM
Compound 3 ended at the assay's limit; the forecaster's own chance of this, stated with the estimate: 35%; middle value at least 1.7-fold (0.25 log units) from the limit.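

In this assay, for the compounds shown here, trifluoromethyl in place of fluoro on this aromatic carbon, para to a large group, gives an at least 4.0-fold higher number from compound 2 to compound 3 (0.60 log units; beyond the scatter), the first readable step. As far as these compounds go, compound 3 is known only as a limit, so this step gives a minimum size and its full size stays unknown. The step from compound 1 to compound 3 cannot be read, so any contribution of the 3,4,5-trimethoxyphenyl group with trifluoromethyl in place stays hidden, since both values are limits: the limit of > 50000 nM in this assay, at which 2 of the 3 values shown sit.

Open, from the compounds shown here alone, is whether the loss is specific to trifluoromethyl: a chloro, methoxy or amine group on this carbon would place other groups against fluoro. Also open, going by these compounds, is what the 3,4,5-trimethoxyphenyl group contributes with fluoro in place, which a phenyl analogue of compound 2 would show.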